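A few compounds are considered here, and "the series" means these few. Any claim that something is new, unique, unknown or untested is made for them only; others in the source may bear on it.

Measured so far:
compound 1, `O=C(Nc1cccc(-n2cc(-c3ccncc3)c(-c3ccc(Cl)c(O)c3)n2)c1)Nc1cccc(C(F)(F)F)c1`, > 32500 nM
compound 2, `COc1cc(-c2nn(-c3cccc(NC(=O)Nc4cc(C(F)(F)F)cc(C(F)(F)F)c4)c3)cc2-c2ccncc2)ccc1Cl`, 3340 nM

Of the compounds shown here, two sharing one core have been tested in a functional assay on NCI-H23 cells (Homo sapiens) for inhibition, read by sulforhodamine B assay, with a stated time of 48 h; on this read-out higher numbers stand for weaker inhibition of growth and lower numbers for stronger inhibition of growth. Compound 1 reaches only the limit of that assay, > 32500 nM, so for compound 1 no number is known. Compound 2 gives 3340 nM in this assay, the only number shown. The other value, that of compound 1, is a limit (the limit of > 32500 nM in this assay, at which 1 of the 2 values shown sits). Compound 2 therefore cannot be ranked against compound 1 beyond that fact.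

The next compound, compound 3, `O=C(Nc1cccc(-n2cc(-c3ccncc3)c(-c3ccc(Cl)c(O)c3)n2)c1)Nc1cc(C(F)(F)F)cc(C(F)(F)F)c1`, is to be measured in this assay. It differs from compound 2 in one place: hydrogen in place of methyl on an oxygen on an aromatic ring, so that 4-chloro-3-methoxyphenyl becomes 4-chloro-3-hydroxyphenyl.

Going by the values given here, no measured pair shows this change on its own, so the size of the step is uncertain. Compound 1 carries the hydroxy group and sits at the limit, which points toward weaker inhibition. The step of a 3.6-fold higher number from compound 2 to compound 3 (0.56 log units; beyond the scatter) is therefore expected to go toward weaker growth inhibition, by more than the usual scatter. Compound 3 is estimated at about 12000 nM, within a range of 3500 nM to 40000 nM.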

Compound 3, concentration for total growth inhibition: 3270 nM
Compound 3: the middle estimate sits 3.7-fold (0.56 log units) above what was measured, and the stated range ends above it.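

In this assay, methoxy to hydroxy on the aromatic ring gives a 1.0-fold lower number from compound 2 to compound 3 (0.01 log units; within the scatter), so with two trifluoromethyl groups on the far ring, this position accepts either group with no difference that can be read. Going by these compounds alone, the hydroxy group therefore cannot, by itself, be what sets compound 1 apart, as the earlier pair seemed to suggest; the single change that separates the two hydroxy compounds, trifluoromethyl in place of hydrogen on an aromatic carbon, gives an at least 9.9-fold lower number from compound 1 to compound 3 (0.99 log units; beyond the scatter), a step beyond the scatter and the first sign that this second group matters. The figure for compound 1 is a limit and not a number, so this step has only a lower bound: the limit of > 32500 nM in this assay, at which 1 of the 3 values shown sits.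

The compounds shown leave open whether the match between methoxy and hydroxy also holds with a single trifluoromethyl group on the far ring, and whether that group's step holds with methoxy in place of hydroxy. They also leave open how an amine or a longer chain such as ethoxy would behave in place of methoxy or hydroxy on this ring.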